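The source may hold more compounds than are shown below. What is called first, only, known or untested is meant among the compounds shown, and "the series" means these compounds.

Measured compounds:
Compound 1 `N/C(=N\NC(=S)N1CCCC1)c1ccc(F)cn1`: 85.6%
Compound 2 `Cc1cccc(/C(N)=N/NC(=S)N2CCCCC2)n1`: 77.5%
Compound 3 `Cc1cccc(/C(N)=N/NC(=S)N2CCCCCC2)n1`: 76.7%

In a functional assay on A-431 cells (Homo sapiens) for cytotoxicity, read by MTT assay, with a stated time of 72 h, tested at 100 uM (a lower number here means less inhibition of growth, a higher number more inhibition of growth at the concentration tested), compound 1 gives 85.6%, and the values of compound 2 and compound 3 both sit within the usual scatter of that number, so the three compounds cannot be told apart on this read-out. Compound 4 `N/C(=N\NC(=S)N1CCOCC1)c1ccc(F)cn1` has not yet been measured. It differs from compound 1 by morpholin-4-yl in place of pyrrolidin-1-yl on a thiocarbonyl carbon. For the measured compounds named here, no pair among the measured compounds shows the same change, so there is nothing to set its size against; the step from compound 1 to compound 4 in this assay is expected to stay within the scatter, as a number 5.6 percentage points lower from compound 1 to compound 4 (within the scatter). Compound 4 is therefore estimated at 80%, within a range of 65% to 92%.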

Compound 4, percent growth inhibition at one concentration: 85.6%
Estimate against measurement, compound 4: 5.6 percentage points below, and the stated range covers the measured number.
By their numbers in this assay, from the lowest: compounds 3, 2, 1 and 4 (each within the scatter of the next).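

In this assay, for the compounds shown here, the step with morpholin-4-yl in place of pyrrolidin-1-yl on a thiocarbonyl carbon reads no change at the digits printed from compound 1 to compound 4 (within the scatter) and gives the first single-place comparison in this set. At this position and this one concentration, the larger ring with its added oxygen and hydrogen-bond acceptor leaves the read-out unmoved. No measurement shown bears on why this is so. As far as these compounds go, whether a piperazin-1-yl ring or an open-chain dimethylamino group on the same carbon would behave alike remains open.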